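The compounds below may be only part of what the source reports. "The series", "measured", "known", "first", "only" and "open" are said of these compounds alone.

Measured compounds:
compound 1 `Fc1cccc(F)c1Cn1c(-c2c(F)cccc2F)nc2c(Br)cccc21`: 24.5 uM
compound 2 `CC(C)c1cccc2c1nc(-c1c(F)cccc1F)n2Cc1c(F)cccc1F`: 27 uM

For the measured compounds named here, in a toxicity assay on CCRF-CEM cells (Homo sapiens) for cytotoxicity (on this read-out higher numbers stand for lower toxicity in this test and lower numbers for higher toxicity in this test), compound 1 gives 24.5 uM, while compound 2 gives 27 uM; the two numbers lie within the scatter of each other, so compound 1 stands level with the only other measured compound rather than apart from it. Compound 3 `NCc1cccc2c1nc(-c1c(F)cccc1F)n2Cc1c(F)cccc1F` has not yet been measured in this assay. It differs from compound 1 in one place: aminomethyl in place of bromo on an aromatic carbon. Going by the values given here, no measured compound carries an aminomethyl, so the only step that bears on this change is a 1.1-fold higher number from compound 1 to compound 2 (0.04 log units; within the scatter), in which a different group took the same position without moving the number beyond the scatter. The entering group here brings a hydrogen-bond donor and acceptor that the isopropyl did not, so the precedent is indirect. On that basis the expected outcome for compound 3 in this assay is a 1.2-fold higher number from compound 1 to compound 3 (0.09 log units; within the scatter), meaning no step beyond the scatter, with a wide range to reflect the untested group. Compound 3 is therefore estimated at 30 uM, with a range from 12 uM to 75 uM.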

Compound 3, half-maximal toxic concentration: 49.3 uM
The estimate for compound 3 lay 1.6-fold (0.22 log units) below the measured number; the range from low to high includes it.
By their numbers in this assay, from the lowest: compounds 1, 2 and 3 (each within the scatter of the next).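

In this assay, aminomethyl in place of bromo on an aromatic carbon gives a 2.0-fold higher number from compound 1 to compound 3 (0.30 log units; within the scatter) and aminomethyl in place of isopropyl at the same position gives a 1.8-fold higher number from compound 2 to compound 3 (0.26 log units; within the scatter) and so neither step leaves the scatter. This position has now carried three groups, and the entering aminomethyl brings a hydrogen-bond donor and a hydrogen-bond acceptor where the bromo had neither, yet compounds 1, 2 and 3 still stand level on this read-out, with none of the three going against that. Nothing measured here speaks to why these three compounds stand level in this test.

The compounds shown leave open whether a carboxylic acid, a dimethylaminomethyl group or a longer chain ending in an amine at this position would also stay within the scatter of these three. For the compounds shown here, they also leave open whether the same holds once the rest of the shared core is changed, as all three compounds carry it unaltered and differ only in the one group on the aromatic carbon.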